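The source may report more compounds than this note shows. Statements on the series, on what has been measured and on what is new or still open speak of the compounds shown alone.

Compound 1 `Cc1ccccc1Nc1nc(SCc2cn(Cc3ccc(Cl)cc3)nn2)nc(-c2ccccc2)c1C#N` was examined in a functional assay on MGC-803 cells (Homo sapiens) for inhibition, read by MTT assay, with a stated time of 72 h; on this read-out higher numbers stand for weaker inhibition and lower numbers for stronger inhibition. In this assay compound 1 gives only a limit, > 64000 nM. Compound 2 `Cc1ccc(Cn2cc(CSc3nc(Nc4ccccc4C)c(C#N)c(-c4ccccc4)n3)nn2)cc1` differs from compound 1 by methyl in place of chloro on an aromatic carbon. In this assay compound 2 likewise gives only a limit, > 64000 nM. The step that the two limits leave unreadable from compound 1 to compound 2 therefore cannot be sized. Compound 3 `N#Cc1c(Nc2ccccc2F)nc(SCc2cn(Cc3ccc(Cl)cc3)nn2)nc1-c1ccccc1` differs from compound 1 by fluoro in place of methyl on an aromatic carbon. In this assay compound 3 also gives only a limit, > 64000 nM. The step that the two limits leave unreadable from compound 1 to compound 3 is equally unreadable. What the three share is the limit of > 64000 nM in this assay, at which 3 of the 3 values shown sit. Compound 4 `Cc1ccc(Cn2cc(CSc3nc(Nc4ccccc4F)c(C#N)c(-c4ccccc4)n3)nn2)cc1` is not yet measured; it differs from compound 3 by methyl in place of chloro on an aromatic carbon, the same change as that from compound 1 to compound 2. Because every measured compound sits at the limit of > 64000 nM in this assay, at which 3 of the 3 values shown sit, compound 4 is expected to show a step that the limit leaves unreadable from compound 3 to compound 4. Compound 4 is estimated at 90000 nM, most likely again reported only as a limit.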

Compound 4, half-maximal inhibitory concentration: 22900 nM
The estimate for compound 4 lay 3.9-fold (0.59 log units) above the measured number, outside the stated range (below it).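

In this assay, methyl in place of chloro on an aromatic carbon gives an at least 2.7-fold lower number from compound 3 to compound 4 (0.44 log units; beyond the scatter), and fluoro in place of methyl on an aromatic carbon gives an at least 2.7-fold lower number from compound 2 to compound 4 (0.44 log units; beyond the scatter). Going by these compounds, the change from 4-chlorobenzyl to 4-methylbenzyl thus has one readable case, on the core of compound 3, and its full size stays unknown, as compound 3 gives only a limit. Whether the change carries over to the core of compound 1 is not shown, because the earlier steps, including the one to compound 2, cannot be read: the limit of > 64000 nM in this assay, at which 3 of the 4 values shown sit.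

Compound 4 is the only one of the four with a number. On these data alone, it remains open how a methoxy, a trifluoromethyl or an ethyl group would read in place of its methyl.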